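Benzylation of the thiosemicarbazone tail in two core isomers

This account rests on a few compounds, and the source may have more. Where it says the series, first, only, none or still open, it means among the compounds named here.

Compound 1 `Cc1cccc(NC2=C/C(=N/NC(N)=S)C(=O)N=C2Nc2cccc(C)c2)c1` carries a shared core with a small thiosemicarbazone tail; in a functional assay on MCF7 cells (Homo sapiens) for antiproliferative activity, read by MTT assay, with a stated time of 72 h (on this read-out lower numbers stand for stronger inhibition and higher numbers for weaker inhibition), compound 1 gives 150 nM. Compound 3 `Cc1cccc(NC2=C/C(=N/N=C(\N)SCc3ccccc3)C(=O)N=C2Nc2cccc(C)c2)c1` differs from compound 1 by a group of 11 heavy atoms (8 carbon, 2 nitrogen, 1 sulfur; one six-membered aromatic ring of carbon only) in place of a group of 4 heavy atoms (1 carbon, 2 nitrogen, 1 sulfur; no ring), on a double-bonded nitrogen, and this change gave a 62-fold higher number from compound 1 to compound 3 (1.79 log units; beyond the scatter). Compound 2 `Cc1ccc(NC2=C/C(=N/NC(N)=S)C(=O)N=C2Nc2ccc(C)cc2)cc1` has the same atoms as compound 1 joined differently; how the two cores differ is not broken down here. In this assay compound 2 gives 3060 nM, and compound 3 gives 9340 nM. Compound 4 `Cc1ccc(NC2=C/C(=N/N=C(\N)SCc3ccccc3)C(=O)N=C2Nc2ccc(C)cc2)cc1` differs from compound 2 by a group of 11 heavy atoms (8 carbon, 2 nitrogen, 1 sulfur; one six-membered aromatic ring of carbon only) in place of a group of 4 heavy atoms (1 carbon, 2 nitrogen, 1 sulfur; no ring), on a double-bonded nitrogen, the same change made on the other core. A large weakening step is expected from compound 2 to compound 4, about a 20-fold higher number from compound 2 to compound 4 (1.29 log units; beyond the scatter), because the same change on compound 1 gave a 62-fold higher number from compound 1 to compound 3 (1.79 log units; beyond the scatter). Compound 4 is therefore expected to give roughly 60000 nM, with a plausible range from 15000 nM to 200000 nM.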

Compound 4, half-maximal inhibitory concentration: 13400 nM
Compound 4: middle estimate off by 4.5-fold (0.65 log units), on the high side; the whole stated range lies above it.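

In this assay, the larger tail with its carbon-only aromatic ring again gives a higher number on the second core, with a 4.4-fold higher number from compound 2 to compound 4 (0.64 log units; beyond the scatter). The direction of the change therefore carries over between these two cores, but its size does not: the same change on two cores in this assay, a 62-fold higher number (1.79 log units; beyond the scatter) from compound 1 to compound 3 and a 4.4-fold higher number (0.64 log units; beyond the scatter) from compound 2 to compound 4, 14-fold (1.15 log units) apart, beyond the scatter of two such steps This shows that the cost of the change depends on the core in this pair, but it does not show why, and two cores give no rule for predicting the size on a third.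

The compounds shown leave open whether a tail ending in a methyl group instead of the aromatic ring would cost as much on either core. Going by these compounds, how the change behaves on a core carrying chlorine in place of the methyl groups also remains open.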